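The source may hold more compounds than are shown below. What is called first, only, known or untested is meant among the compounds shown, and "the series" means these compounds.

Series notes. Three compounds share a core built around a thiophene-fused ring bearing a primary amide, and all three have been run in a functional assay (strain AB) with Danio rerio as the target, read by microscopy, with a stated time of 1 h; on this read-out higher numbers stand for an effect only at larger amounts of compound and lower numbers for an effect already at smaller amounts. Compound 1 `CC(C)(C)C[N+]1(C)CCc2c(sc(NC(=O)Nc3ccc(Cl)cc3)c2C(N)=O)C1` gives 290 nM. Compound 3 `CC1(C)Cc2c(sc(NC(=O)Nc3ccc(Cl)cc3)c2C(N)=O)C(C)(C)N1` gives 1240 nM. Compound 2 `CCN1CCc2c(sc(NC(=O)Nc3ccc(Br)cc3)c2C(N)=O)C1` gives 3130 nM, the highest of the three numbers: its nearest neighbour is compound 3, and the gap to compound 3 as well as the larger gap to compound 1 lies beyond the scatter, so compound 2 is the weakest of the three measured.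

The next compound, compound 4 `CCN1CCc2c(sc(NC(=O)c3ccccc3)c2C(N)=O)C1`, is compound 2 with one change: phenyl in place of (4-bromophenyl)amino on a carbonyl carbon. The urea of compound 2 becomes a benzamide, and the bromine on the aromatic ring is gone. Every measured compound carries a urea with a halogen on the outer ring, so no measured pair isolates either part of this change; the expectation rests on that absence rather than on a shown step.

The expectation is a further move toward weaker activity, beyond the scatter, from compound 2 to compound 4, estimated as a 2.9-fold higher number from compound 2 to compound 4 (0.46 log units; beyond the scatter). For compound 4 the expected value in this assay is 9000 nM, with a range of 2500 nM to 32000 nM.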

Compound 4, half-maximal effective concentration: > 25000 nM
Compound 4 ended at the assay's limit (the forecaster's own chance of this, stated with the estimate: 20%); at least 2.7-fold (0.44 log units) between middle value and limit.
By their numbers in this assay, from the lowest: compound 1; then compound 3; then compound 2. At a limit, above all of these: compound 4.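

In this assay compound 4 stands at > 25000 nM, which is a limit of the assay and not a number: the limit of > 25000 nM in this assay, at which 1 of the 4 values shown sits. Phenyl in place of (4-bromophenyl)amino on a carbonyl carbon gives an at least 7.9-fold higher number from compound 2 to compound 4 (0.90 log units; beyond the scatter), the first step that can be read at this position, and it shows that activity here responds to this change, with the true size of the step still unknown beyond that bound. The change removes the nitrogen, its hydrogen-bond donor and the bromine together, so this single step does not assign the shift to any one of them.

The compounds shown leave open which of these parts carries the shift. Phenylamino on the same carbonyl carbon would keep the nitrogen without the bromine, and 4-bromophenyl there would keep the bromine without the nitrogen.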